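Swapping the ring carbonyl partner in compound 1

The source may report more compounds than this note shows. Statements on the series, on what has been measured and on what is new or still open speak of the compounds shown alone.

Compound 1 `CC(C)(C)c1cc(NC(=O)N2CCCN(C(=O)C3CCOCC3)CC2)no1` was run in an in vitro ADME assay on microsomes from liver (Homo sapiens) for metabolic stability, read by LC-MS; on this read-out lower numbers stand for a shorter-lived compound and higher numbers for a longer-lived compound. In this assay compound 1 gives > 2 h, which is a limit of the assay rather than a number (the limit of > 2 h in this assay, at which 1 of the 2 values shown sits). Compound 2 `CC(C)(C)c1cnc(NC(=O)N2CCCN(C(=O)C3CCOCC3)CC2)s1` was measured in the same assay, and compound 2 gives 0.45 h. Among the measured compounds shown here, the only measured step, an at least 4.4-fold lower number from compound 1 to compound 2 (0.64 log units; beyond the scatter), concerns the five-membered aromatic ring on the amide-type nitrogen and leaves the rest of the molecule untouched.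

Compound 3 `CC(C)(C)c1cc(NC(=O)N2CCCN(C(=O)N3CCOCC3)CC2)no1` differs from compound 1 elsewhere: morpholin-4-yl in place of oxan-4-yl on a carbonyl carbon. Read one bond further out, this is (oxan-4-yl)carbonyl to (morpholin-4-yl)carbonyl, while the five-membered ring of compound 1 is kept. For the measured compounds named here, no measured step touches this position, so the pair of compounds 1 and 2 offers no direct guide to its size or direction. With only the limit of compound 1 as anchor, the expected step from compound 1 to compound 3 is one of no change beyond the scatter, a step that the limit leaves unreadable from compound 1 to compound 3. Compound 3 is therefore estimated at 2.5 h in this assay, with a range from 1.2 h to 6 h, and the assay may again report only a limit.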

Compound 3, half-life: 0.967 h
Beside the measured number, compound 3's estimate is 2.6-fold (0.41 log units) above it; measured number below the stated range.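

In this assay, the change from oxan-4-yl to morpholin-4-yl on a carbonyl carbon gives an at least 2.0-fold lower number from compound 1 to compound 3 (0.31 log units; beyond the scatter). The five-membered aromatic ring on the amide-type nitrogen is therefore not the only place where this read-out moves, since the (oxan-4-yl)carbonyl end of the molecule also responds while the ring of compound 1 is kept. The full size of the step cannot be read, and the printed figure is only a floor, because compound 1 stands at a limit of the assay rather than at a number: the limit of > 2 h in this assay, at which 1 of the 3 values shown sits.

The compounds shown leave open whether the morpholin-4-yl change would have a similar effect on the core of compound 2, which carries the other five-membered ring, and they do not show which difference between the two six-membered rings underlies the step. From the compounds shown here alone, it also remains open how the half-life would respond to a piperidin-1-yl ring or an open-chain dimethylamino group on the same carbonyl carbon, either of which would help separate the role of the ring nitrogen from that of the ring oxygen.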